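A Methyl on the Aromatic Ring of the Shared Core

The compounds below may be only part of what the source reports. "The series", "measured", "known", "first", "only" and "open" are said of these compounds alone.

Compound 3 `N#CC1=C(N)Oc2cc3oc(-c4ccccc4)cc(=O)c3c(O)c2C12C(=O)Nc1ccccc12` is the only one of the three measured compounds for which an actual number stands. In a functional assay on A549 cells (Homo sapiens) for antiproliferative activity, read by MTT assay, with a stated time of 48 h (a higher number here means a weaker inhibitor, a lower number a stronger inhibitor), compound 3 gives 37600 nM. Compound 1 `Cc1ccc2c(c1)C1(C(=O)N2Cc2ccccc2)C(C#N)=C(N)Oc2cc3oc(-c4ccccc4)cc(=O)c3c(O)c21` reaches only the limit of this assay, giving > 50000 nM. Compound 2 `CCN1C(=O)C2(C(C#N)=C(N)Oc3cc4oc(-c5ccccc5)cc(=O)c4c(O)c32)c2cc(C)ccc21` likewise reaches only the limit, giving > 50000 nM. Thus (the limit of > 50000 nM in this assay, at which 2 of the 3 values shown sit), and compound 3 is the sole anchor for any expectation.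

For the measured compounds named here, the one measured step that changes the shared core in a single place, a step that the two limits leave unreadable from compound 1 to compound 2, is unreadable, so its size cannot guide the next move. Compound 4 `Cc1ccc2c(c1)C1(C(=O)N2)C(C#N)=C(N)Oc2cc3oc(-c4ccccc4)cc(=O)c3c(O)c21` differs from compound 3 by methyl in place of hydrogen on an aromatic carbon. Going by the values given here, no measured step touches that part of the shared core, and so the reasonable expectation is a step of no size beyond the usual scatter in this assay. Compound 4 is therefore expected to give about 40000 nM in this assay, within 18000 nM to 90000 nM. That corresponds to an expected step of a 1.1-fold higher number from compound 3 to compound 4 (0.03 log units; within the scatter), with a real chance that only a limit is reported.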

Compound 4, half-maximal inhibitory concentration: > 50000 nM
Compound 4 gave a limit, no number (the forecaster's own chance of this, stated with the estimate: 40%); middle value at least 1.2-fold (0.09 log units) from the limit.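

In this assay, for the compounds shown here, methyl in place of hydrogen on an aromatic carbon gives the first step at this position that can be read at all, and only as a floor, an at least 1.3-fold higher number from compound 3 to compound 4 (0.12 log units; that floor lies within the scatter), so the methyl compound cannot be separated from its parent. The amide hydrogen, which compound 3 also carries, does not lift compound 4 off the limit, and the steps from compound 1 and from compound 2 to compound 4 cannot be read. Most of the set now rests on a single boundary: (the limit of > 50000 nM in this assay, at which 3 of the 4 values shown sit).

As far as these compounds go, how far compound 4 truly lies from compound 3 stays open, as its result is a limit and not a number. Also open, from the compounds shown here alone, is what chlorine, a methoxy group or an amine would give on this same aromatic carbon.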